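Series notes: from compound 3 to compound 4

The compounds below may be only part of what the source reports. "The series", "measured", "known", "first", "only" and "open" are said of these compounds alone.

Compound 1 `O=C(O)c1ccc(-c2cnc(C(=O)CCCCCCc3ccccc3)o2)cc1` gives 60 nM in an assay (Rattus norvegicus) for inhibition of Fatty-acid amide hydrolase 1 (Homo sapiens); a lower number here means a stronger inhibitor, a higher number a weaker inhibitor.
Compound 2 `NC(=O)c1ccc(-c2cnc(C(=O)CCCCCCc3ccccc3)o2)cc1` gives 10 nM in this assay.
Compound 3 `N#Cc1ccc(-c2cnc(C(=O)CCCCCCc3ccccc3)o2)cc1` gives 40 nM in this assay.

Compound 3 stands second highest of the three numbers, nearest compound 1 and furthest from compound 2; its step to compound 1 lies within the scatter, its step from compound 2 beyond it. Compound 4 `NS(=O)(=O)c1ccc(-c2cnc(C(=O)CCCCCCc3ccccc3)o2)s1` differs from compound 3 by 5-sulfamoylthiophen-2-yl in place of 4-cyanophenyl on an aromatic carbon. The step that bears on this is a 4.0-fold higher number from compound 2 to compound 3 (0.60 log units; beyond the scatter), where the group carrying a hydrogen-bond donor gave the lower number; a 1.5-fold lower number from compound 1 to compound 3 (0.18 log units; within the scatter) lay within the scatter. A sulfamoyl group again carries a donor, so a lower number is expected for compound 4, with the step of a 2.7-fold lower number from compound 3 to compound 4 (0.43 log units; beyond the scatter). Compound 4 is thus estimated at 15 nM, within 5 nM to 45 nM.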

Compound 4, inhibition constant: 3 nM
Compound 4: middle estimate off by 5.0-fold (0.70 log units), on the high side, and the stated range ends above it.
By their numbers in this assay, from the lowest: compound 4; then compound 2; then compounds 3 and 1 (each within the scatter of the next).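

In this assay, 5-sulfamoylthiophen-2-yl at this position gives a 13-fold lower number from compound 3 to compound 4 (1.12 log units; beyond the scatter) and a 20-fold lower number from compound 1 to compound 4 (1.30 log units; beyond the scatter), so the aromatic group here can change in both ring and substituent without loss. It also gives a 3.3-fold lower number from compound 2 to compound 4 (0.52 log units; beyond the scatter), so the 4-carbamoylphenyl result did not mark the lowest number reachable at this position. Nothing available accounts for the size of these steps. Ring and substituent change together, so their shares in the gain remain unseparated. A sulfamoyl group on a six-membered aromatic ring, or a carboxylic acid on the five-membered ring, would separate them.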